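The source may report more compounds than this note shows. Statements on the series, on what has been measured and on what is new or still open speak of the compounds shown alone.

Compound 1 `O=C(NCc1cn(Cc2ccc(C(F)(F)F)cc2)nn1)c1cn(-c2ccccc2)nc1-c1ccc(F)cc1` is the starting point. In a functional assay on MCF7 cells (Homo sapiens) for antiproliferative activity, read by sulforhodamine B assay, with a stated time of 48 h (on this read-out higher numbers stand for weaker inhibition of growth and lower numbers for stronger inhibition of growth), compound 1 gives 810 nM, the higher of the two numbers shown, although the step of a 1.2-fold lower number from compound 1 to compound 2 (0.10 log units; within the scatter) lies within the scatter. Compound 2 `COc1ccc(Cn2cc(CNC(=O)c3cn(-c4ccccc4)nc3-c3ccc(F)cc3)nn2)cc1` in this assay gives 650 nM. Compound 3 `COc1ccc(Cn2cc(CNC(=O)c3cn(-c4ccccc4)nc3-c3ccc(F)cc3)nn2)cc1OC` in this assay gives only a limit, > 100000 nM, and the limit of > 100000 nM in this assay, at which 1 of the 3 values shown sits, is where that value sits. The steps of an at least 120-fold higher number from compound 1 to compound 3 (2.09 log units; beyond the scatter) and an at least 150-fold higher number from compound 2 to compound 3 (2.18 log units; beyond the scatter) are both large.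

Compound 4 `COc1ccc(-c2nn(-c3ccccc3)cc2C(=O)NCc2cn(Cc3ccc(C(F)(F)F)cc3)nn2)cc1` differs from compound 1 by methoxy in place of fluoro on an aromatic carbon. Within the data shown here, none of the measured steps touches this position: all three alter the aryl group on the saturated chain carbon bound to an aromatic nitrogen, where a methoxy in place of trifluoromethyl gave a 1.2-fold lower number from compound 1 to compound 2 (0.10 log units; within the scatter), within the scatter, whereas a further methoxy in place of hydrogen gave an at least 150-fold higher number from compound 2 to compound 3 (2.18 log units; beyond the scatter), far beyond it. For the exchange of fluoro for methoxy on the aryl ring attached to the shared core no comparison exists. The only measured single methoxy-for-halogen type change moved the number little, so for compound 4 no step beyond the scatter is expected, as a 1.5-fold higher number from compound 1 to compound 4 (0.17 log units; within the scatter), with wide uncertainty. Compound 4 is therefore estimated at 1200 nM, between 300 nM and 6000 nM.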

Compound 4, concentration for 50% growth inhibition: > 100000 nM
Compound 4: no number, only a limit; the forecaster's own chance of this, stated with the estimate: 10%; middle value at least 83-fold (1.92 log units) away from the limit.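

Among these compounds, until this result, only the aryl group on the saturated chain carbon bound to an aromatic nitrogen had been changed; compound 4 shows that the aryl group on the shared core also matters, with the change from 4-fluorophenyl to 4-methoxyphenyl giving an at least 120-fold higher number from compound 1 to compound 4 (2.09 log units; beyond the scatter) in this assay. The same entering group behaved very differently at the other aryl ring, where methoxy in place of trifluoromethyl gave a 1.2-fold lower number from compound 1 to compound 2 (0.10 log units; within the scatter), so methoxy is not accepted equally at both places in this series. The value of compound 4 is a limit and not a number, and compound 3 sits at the same limit: the limit of > 100000 nM in this assay, at which 2 of the 4 values shown sit.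

The compounds shown leave open whether the loss of fluoro or the arrival of methoxy accounts for this step, since only these two groups appear on this ring. They also leave open whether a hydroxy, a chloro, a methyl or an amine at this place of the ring would keep the growth inhibition seen for compound 1 or would fall to the same limit as compound 4.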